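The compounds below may be only part of what the source reports. "The series", "measured", "known", "first", "only" and "open" are said of these compounds alone.

Measured so far:
- compound 1, `ClCc1ccc(Cn2cnc3c(Cl)ncnc32)cc1`: 24000 nM
- compound 2, `ClCc1ccc(Cn2cnc3nc(Cl)nc(Cl)c32)cc1`: 5880 nM
- compound 3, `ClCc1ccc(Cn2cnc3c(Cl)nc(Cl)nc32)cc1`: 44700 nM

All three were read in a functional assay on SF-295 cells (Homo sapiens) for cytotoxicity, read by sulforhodamine B assay, with a stated time of 48 h; a higher number here means that more compound is tolerated, a lower number that less compound is tolerated. Compound 2 gives the lowest number of the three; compound 1 and compound 3 both stand beyond the scatter above it. How the core of compound 2 differs from the core of compound 3 is not broken down here.

Compound 3 and compound 1 differ in one place, (hydrogen in place of chloro on an aromatic carbon). This step gave a 1.9-fold lower number from compound 3 to compound 1 (0.27 log units; within the scatter), a step that stays within the usual scatter of this assay.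

Compound 4, `ClCc1ccc(Cn2cnc3ncnc(Cl)c32)cc1`, is not yet measured in this assay. It is made from compound 2 by the same change, (hydrogen in place of chloro on an aromatic carbon), at a place that is described in the same words as for the pair above.

For the measured compounds named here, on the single precedent, the step from compound 2 to compound 4 is expected to be small, a 1.3-fold lower number from compound 2 to compound 4 (0.12 log units; within the scatter), because the same change gave only a 1.9-fold lower number from compound 3 to compound 1 (0.27 log units; within the scatter). Compound 4 is therefore estimated at 4500 nM, with a plausible range from 1800 nM to 11000 nM. A single precedent is thin ground; any larger step in either direction would not be surprising.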

Compound 4, concentration lethal to 50% of the cells: 17000 nM
Estimate against measurement, compound 4: 3.8-fold (0.58 log units) below; measured number above the stated range.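

The change of chloro to hydrogen on an aromatic carbon did not carry over in size or direction between the two cores in this assay: the same change on two cores in this assay, a 1.9-fold lower number (0.27 log units; within the scatter) from compound 3 to compound 1 and a 2.9-fold higher number (0.46 log units; beyond the scatter) from compound 2 to compound 4, 5.4-fold (0.73 log units) apart, beyond the scatter of two such steps. The new step (a 2.9-fold higher number from compound 2 to compound 4 (0.46 log units; beyond the scatter)) is therefore no repeat of the earlier one, and a step read on one core gave no safe estimate for the other in this series. This rests on a single pair per core: it shows that the outcome of the change depends on the core in these two cases, but it does not show what in the cores sets them apart or how the change would run on a further core.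

The compounds shown carry only chloro or hydrogen at the changed carbon, so it remains open how an amine, a methoxy group or a thioether would read there. Also open, going by these compounds, is whether the difference between the two cores would hold with something other than the chloromethyl group on the benzene ring, such as a longer chain or a carboxylic acid.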